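Sulfonamide ring swapped for a lactam on the shared core

The source may hold more compounds than are shown below. What is called first, only, known or untested is meant among the compounds shown, and "the series" means these compounds.

Measured compounds:
compound 1 `CC(C)C(c1ccc(-c2ccc3cccc(F)c3c2)[nH]c1=O)N1CCCCS1(=O)=O`: 0.07 h
compound 2 `CC(C)C(Cc1nnn[nH]1)c1ccc(-c2ccc3cccc(F)c3c2)[nH]c1=O`: 2.08 h

In an ADME assay on microsomes from liver (Rattus norvegicus) for metabolic stability (on this read-out higher numbers stand for a longer-lived compound and lower numbers for a shorter-lived compound), compound 1 gives 0.07 h, the lowest of the two numbers recorded. Among the compounds with values here, its nearest neighbour is compound 2, which in this assay gives 2.08 h; the step is a 30-fold higher number from compound 1 to compound 2 (1.47 log units; beyond the scatter), the only measured step in the set.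

Compound 3 `CC(C)C(/C=C1\CCNC1=O)c1ccc(-c2ccc3cccc(F)c3c2)[nH]c1=O` is not yet measured. It differs from compound 1 as follows: a group of 7 heavy atoms (5 carbon, 1 nitrogen, 1 oxygen; one five-membered non-aromatic ring with 1 hetero atom) in place of a group of 8 heavy atoms (4 carbon, 1 nitrogen, 2 oxygen, 1 sulfur; one six-membered non-aromatic ring with 2 hetero atoms), on a saturated chain carbon bound to an aromatic carbon and a saturated chain carbon. The leaving group is the same one that was replaced on the way from compound 1 to compound 2, so the step of a 30-fold higher number from compound 1 to compound 2 (1.47 log units; beyond the scatter) bears on this change, though the entering group here is a different one: a five-membered non-aromatic ring with one hetero atom carrying one hydrogen-bond donor, rather than the five-membered aromatic ring with four hetero atoms of compound 2. Within the data shown here, the one relevant step points upward and is large, so a rise beyond the scatter is expected, but a smaller one than for compound 2, with wide uncertainty.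

For compound 3 the expected value in this assay is 0.4 h, with a range from 0.08 h to 2 h, which corresponds to an expected step of a 5.7-fold higher number from compound 1 to compound 3 (0.76 log units; beyond the scatter).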

Compound 3, half-life: 0.345 h
The estimate for compound 3 lay 1.2-fold (0.06 log units) above the measured number; measured number inside the range.
By their numbers in this assay, from the lowest: compound 1; then compound 3; then compound 2.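

In this assay a second, quite different entering group also lifts the number on the saturated chain carbon bound to an aromatic carbon and a saturated chain carbon, with the five-membered non-aromatic ring with 1 hetero atom giving a 4.9-fold higher number from compound 1 to compound 3 (0.69 log units; beyond the scatter) in place of the six-membered non-aromatic ring with 2 hetero atoms. The rise therefore does not belong to the five-membered aromatic ring with 4 hetero atoms alone, yet the two entering groups are not interchangeable, since the exchange between them gives a 6.0-fold lower number from compound 2 to compound 3 (0.78 log units; beyond the scatter), so what enters at this place sets how far the number climbs. Nothing measured here accounts for the gap between the two entering groups or for the low number of compound 1.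

The compounds shown leave open whether a carboxylic acid or an open-chain amide at this place would reach the level of compound 2 or stay nearer that of compound 3. They also leave open whether a simple amine or a plain alkyl chain on the same carbon would raise the number at all, which would show how much of the rise needs an entering ring.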